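Swapping hydroxy for carboxymethyl on a saturated chain

This account rests on a few compounds, and the source may have more. Where it says the series, first, only, none or still open, it means among the compounds named here.

Of the compounds shown here, three that share one core have been tested in a functional assay (trachea) with Cavia porcellus as the target; a lower number here means a stronger inhibitor, a higher number a weaker inhibitor. Compound 1 `CCn1nc(-c2cccnc2)c2ccccc2c1=O` gives 1320 nM, compound 2 `O=c1c2ccccc2c(-c2cccnc2)nn1CCSc1ccccc1` gives 9120 nM, and compound 3 `O=c1c2ccccc2c(-c2cccnc2)nn1CCO` gives 4570 nM. The measurements show a 3.5-fold higher number from compound 1 to compound 3 (0.54 log units; beyond the scatter), a real gap, but only a 2.0-fold lower number from compound 2 to compound 3 (0.30 log units; within the scatter), so those last two numbers cannot be told apart.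

Compound 4 `O=C(O)CCCn1nc(-c2cccnc2)c2ccccc2c1=O` alters the side chain of compound 3: carboxymethyl in place of hydroxy on a saturated chain carbon, two bonds along the chain from an aromatic nitrogen. Carboxymethyl takes the place of hydroxy on a saturated chain carbon, two bonds along the chain from an aromatic nitrogen. Among the compounds with values here, no measured pair makes this exact swap, so the evidence is indirect. Two different groups have been placed at this carbon, and both raised the number relative to the hydrogen of compound 1: a 6.9-fold higher number from compound 1 to compound 2 (0.84 log units; beyond the scatter) with phenylsulfanyl, and a 3.5-fold higher number from compound 1 to compound 3 (0.54 log units; beyond the scatter) with hydroxy. Exchanging those two groups for each other moved the number no further than the scatter, which suggests only a limited response to the group at this place, though three compounds are thin support.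

The swap is therefore expected to give a 1.2-fold higher number from compound 3 to compound 4 (0.08 log units; within the scatter), with no step beyond the scatter anticipated. For compound 4 the estimated value is 5500 nM, with an expected range from 1800 nM to 16000 nM.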

Compound 4, half-maximal inhibitory concentration: > 100000 nM
Compound 4 ended at the assay's limit (the forecaster's own chance of this, stated with the estimate: 15%); at least 18-fold (1.25 log units) between middle value and limit.
By their numbers in this assay, from the lowest: compound 1; then compounds 3 and 2 (each within the scatter of the next). At a limit, above all of these: compound 4.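

The first three compounds suggested only a limited response at this carbon, but compound 4 shows that the group placed there can matter a great deal: in this assay, replacing 2-hydroxyethyl with 3-carboxypropyl gives an at least 21-fold higher number from compound 3 to compound 4 (1.34 log units; beyond the scatter), and the exchange for the phenylsulfanyl side chain gives an at least 10-fold higher number from compound 2 to compound 4 (1.04 log units; beyond the scatter). These steps are far larger than the step between the hydroxy and phenylsulfanyl compounds, which stayed within the scatter, and the gap is wider still when carboxymethyl replaces hydrogen at this carbon, with an at least 75-fold higher number from compound 1 to compound 4 (1.87 log units; beyond the scatter). All three steps are only lower bounds, since compound 4 stands at a limit of the assay and not at a number: the limit of > 100000 nM in this assay, at which 1 of the 4 values shown sits.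

The compounds shown cannot separate the carboxylic acid from the longer chain that carries it, as both enter together in this change. On these data alone, a 3-hydroxypropyl chain, a shorter chain ending in the carboxylic acid, or the methyl ester of compound 4 would pull those two apart, and how an amine at the chain end would behave also stays open.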